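Swapping a nitrile for chlorine on the benzyl ring

The source may report more compounds than this note shows. Statements on the series, on what has been measured and on what is new or still open speak of the compounds shown alone.

Compound 1 `Cc1cc(C)c(Oc2cc(Nc3ccc(C#N)cc3)ncc2C(=O)NCc2cn(Cc3ccccc3[N+](=O)[O-])nn2)c(C)c1`: > 212000 nM
Compound 2 `Cc1cc(C)c(Oc2cc(Nc3ccc(C#N)cc3)ncc2C(=O)NCc2cn(Cc3ccccc3C#N)nn2)c(C)c1`: > 219000 nM

In an ADME assay on MT4 cells (Homo sapiens) for cytotoxicity, read by MTT assay, with a stated time of 5 days (a higher number here means that more compound is tolerated, a lower number that less compound is tolerated), compound 1 gives > 212000 nM, which is a limit of the assay rather than a number. In this assay compound 2 gives > 219000 nM, again only a limit. The step that the two limits leave unreadable from compound 1 to compound 2 therefore cannot be read, since both values sit at the limit of > 212000 nM in this assay, at which 1 of the 2 values shown sits, and (the limit of > 219000 nM in this assay, at which 1 of the 2 values shown sits). Compound 2 thus stands at the limit, with no number of its own. Compound 3 `Cc1cc(C)c(Oc2cc(Nc3ccc(C#N)cc3)ncc2C(=O)NCc2cn(Cc3ccccc3Cl)nn2)c(C)c1` differs from compound 2 by chloro in place of cyano on an aromatic carbon. No readable step bears on this change, so compound 3 is expected to stay at the limit in this assay, a step of an at least 1.0-fold lower number from compound 2 to compound 3 (0.00 log units; that floor lies within the scatter). Compound 3 is estimated at 215000 nM, between 100000 nM and 300000 nM.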

Compound 3, half-maximal cytotoxic concentration: >= 188000 nM
Compound 3 gave a limit, no number; the forecaster's own chance of this, stated with the estimate: 85%; the middle value is on the limit's open side.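

Compound 3 also gives only a limit, not a number, so its steps from compound 1 and from compound 2 cannot be read. In this assay the compounds shown leave open whether nitro, cyano or chloro changes the tolerated concentration at all.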